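From 4-methoxyphenyl to 3-methoxyphenyl: cytotoxicity notes

The source may hold more compounds than are shown below. What is called first, only, known or untested is meant among the compounds shown, and "the series" means these compounds.

In an ADME assay on HEK293 cells (Homo sapiens) for cytotoxicity, read by MTT assay, with a stated time of 48 h (a higher number here means a weaker inhibitor, a lower number a stronger inhibitor), compound 1 `COc1ccc(-c2nc(SCC(=O)c3sc(-c4ccccc4)nc3C)[nH]c(=O)c2C#N)cc1` gives 76200 nM. For the measured compounds named here, this is the only number available, so compound 1 cannot yet be ranked against any other compound. Compound 2 `COc1ccc(-c2nc(C)c(C(=O)CSc3nc(N)c(C#N)c(-c4ccccc4)n3)s2)cc1` has the entry "not determined" (no result reported). Compound 3 `COc1ccc(-c2nc(C)c(C(=O)CSc3nc(-c4ccc(OC)cc4)c(C#N)c(=O)[nH]3)s2)cc1` has the entry "not determined" (no result reported). Neither offers a comparison.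

Compound 4 `COc1cccc(-c2nc(SCC(=O)c3sc(-c4ccccc4)nc3C)[nH]c(=O)c2C#N)c1` is still to be measured in this assay. It has the same atoms as compound 1, joined differently: 3-methoxyphenyl in place of 4-methoxyphenyl on an aromatic carbon. In words, 3-methoxyphenyl stands in place of 4-methoxyphenyl on an aromatic carbon of the shared core.

Going by the values given here, no measured pair shows what such a change does. No step beyond the scatter is therefore expected in this assay, and no direction can be argued. The expectation rests on compound 1 alone, at 76200 nM. The estimated change is a 1.1-fold lower number from compound 1 to compound 4 (0.04 log units; within the scatter), which would lie within the scatter. Compound 4 is expected at 70000 nM, with an estimated range of 30000 nM to 150000 nM.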

Compound 4, half-maximal inhibitory concentration: 90200 nM
Compound 4: middle estimate off by 1.3-fold (0.11 log units), on the low side; measured number inside the range.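

Placing 3-methoxyphenyl in place of 4-methoxyphenyl on the aromatic carbon ortho to a cyano group gives the first measured step of the series in this assay: a 1.2-fold higher number from compound 1 to compound 4 (0.07 log units; within the scatter). This single pair therefore provides no basis for separating the two methoxyphenyl groups at this place on the shared core, as the step lies within the scatter. No supporting measurement bears on the result, so it remains an observation without an assigned cause.

From the compounds shown here alone, it remains open whether an amine, a carboxylic acid or a longer chain on this phenyl ring, in place of the methoxy group, would give a step beyond the scatter. Whether the same exchange would behave alike on a different core also remains unanswered by this one pair.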